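The source may hold more compounds than are shown below. What is called first, only, known or untested is meant among the compounds shown, and "the series" means these compounds.

Measured in a functional assay on DU-145 cells (Homo sapiens) for inhibition; on this read-out higher numbers stand for weaker inhibition and lower numbers for stronger inhibition:
- Compound 1 `Oc1ccc(-c2cc(-c3ccccc3F)cc(-c3ccccc3O)n2)cc1`: > 50000 nM (a limit of the assay, not a number)
- Compound 2 `Oc1ccc(-c2cc(-c3ccccc3F)cc(-c3cccc(O)c3)n2)cc1`: 3160 nM
- Compound 3 `Oc1ccc(-c2cc(-c3ccccc3F)cc(-c3ccc(O)cc3)n2)cc1`: 7780 nM

Compound 1 stands at the limit of this assay, and only that limit is known for it. Compound 4 `Oc1ccc(-c2cc(-c3ccccc3C(F)(F)F)cc(-c3ccccc3O)n2)cc1` carries trifluoromethyl in place of fluoro on an aromatic carbon of the core of compound 1 (trifluoromethyl in place of fluoro on an aromatic carbon). Within the data shown here, no measured step touches this place. The large changes, an at least 15-fold lower number from compound 1 to compound 2 (1.19 log units; beyond the scatter) and an at least 6.4-fold lower number from compound 1 to compound 3 (0.80 log units; beyond the scatter), both replace the 2-hydroxyphenyl, which compound 4 keeps. No step beyond the scatter is therefore expected, and compound 4 may also report only a limit. The expected step is an at least 1.2-fold lower number from compound 1 to compound 4 (0.09 log units; that floor lies within the scatter). Compound 4 is estimated at 40000 nM, with an expected range of 10000 nM to 100000 nM.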

Compound 4, half-maximal inhibitory concentration: 6690 nM
Estimate against measurement, compound 4: 6.0-fold (0.78 log units) above, outside the stated range (below it).
By their numbers in this assay, from the lowest: compound 2; then compounds 4 and 3 (each within the scatter of the next). At a limit, above all of these: compound 1.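

In this assay, among these compounds, the earlier steps all moved the hydroxyl of the 2-hydroxyphenyl, whereas this one shows that the other aryl position also matters with that group kept: trifluoromethyl in place of fluoro gives an at least 7.4-fold lower number from compound 1 to compound 4 (0.87 log units; beyond the scatter) on the 2-fluorophenyl position of the shared core. This step is only a floor, as compound 1 stands at a limit of the assay: the limit of > 50000 nM in this assay, at which 1 of the 4 values shown sits.

Going by these compounds, whether a methyl, a chlorine or an amine at this position would act like trifluoromethyl remains open. So does whether trifluoromethyl would have the same effect alongside the 3-hydroxyphenyl or 4-hydroxyphenyl.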